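Trifluoromethyl on the Phenyl Ring: Cytotoxicity Expected Unchanged

The compounds below may be only part of what the source reports. "The series", "measured", "known", "first", "only" and "open" are said of these compounds alone.

Compound 1 `COc1ccc(-c2cc(CO[C@@H]3COc4nc([N+](=O)[O-])cn4C3)on2)cn1` and compound 2 `O=[N+]([O-])c1cn2c(n1)OC[C@@H](OCc1nnn(-c3ccccc3)n1)C2` were both tested in an ADME assay on Vero cells (Chlorocebus sabaeus) for cytotoxicity, with a stated time of 72 h; a lower number here means a stronger inhibitor, a higher number a weaker inhibitor. For compound 1 the result is a limit of the assay rather than a number, > 128000 nM. For compound 2 the result is likewise a limit, > 128000 nM. Compound 2 therefore stands at the limit of > 128000 nM in this assay, at which 2 of the 2 values shown sit. Compound 3 `O=[N+]([O-])c1cn2c(n1)OC[C@@H](OCc1nnn(-c3ccc(C(F)(F)F)cc3)n1)C2` differs from compound 2 by trifluoromethyl in place of hydrogen on an aromatic carbon. In this assay the expected step is a number no higher from compound 2 to compound 3 (the limit leaves the size open), none beyond the usual scatter, since both known values sit at the limit. Compound 3 is expected to give 128000 nM. The estimated range for compound 3 runs from 50000 nM to 300000 nM.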

Compound 3, half-maximal inhibitory concentration: > 128000 nM
Compound 3: no number, only a limit; the forecaster's own chance of this, stated with the estimate: 80%; the middle value lies on the limit itself.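

In this assay, compound 2 and compound 3 both sit at the assay's limit, so no step between them can be read: the limit of > 128000 nM in this assay, at which 3 of the 3 values shown sit.

The compounds shown leave open whether trifluoromethyl in place of hydrogen changes cytotoxicity at all, and at what concentration any of them would inhibit these cells.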